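The source may report more compounds than this note shows. Statements on the series, on what has been measured and on what is new or still open speak of the compounds shown alone.

Measured in a physicochemical assay for solubility, measured as kinetic solubility; a lower number here means a less soluble compound, a higher number a more soluble compound:
compound 1 `Cc1ccc2[nH]c(=O)nc(-c3ccccc3)c2c1`: 80000 nM
compound 2 `CN1CCN(c2ccc3[nH]c(=O)nc(-c4ccccc4)c3c2)CC1`: > 1000000 nM (a limit of the assay)
compound 3 `Cc1ccccc1-c1nc(=O)[nH]c2ccc(-c3cc[nH]n3)cc12`: 13000 nM

Compound 3 (13000 nM) has the lowest number among those shown, and compound 1 stands higher at 80000 nM. Compound 4 `O=c1nc(C2CCC2)c2cc(-c3cc[nH]n3)ccc2[nH]1` carries cyclobutyl in place of 2-methylphenyl on an aromatic carbon. Within the data shown here, no measured step touches this place. The only one, an at least 12-fold higher number from compound 1 to compound 2 (1.09 log units; beyond the scatter), was large but replaced a different group elsewhere, so it guides only loosely. A moderate move to a higher number in this assay is therefore expected, and the estimated step is a 2.3-fold higher number from compound 3 to compound 4 (0.36 log units; beyond the scatter). For compound 4 the estimated value is 30000 nM. The expected range for compound 4 runs from 9000 nM to 100000 nM.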

Compound 4, solubility: 74000 nM
The estimate for compound 4 lay 2.5-fold (0.39 log units) below the measured number; measured number inside the range.
By their numbers in this assay, from the lowest: compound 3; then compounds 4 and 1 (each within the scatter of the next). At a limit, above all of these: compound 2.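

Among these compounds, this is the first step at this place, on the aromatic carbon next to the ring nitrogen, as the only earlier step changed a different group. In this assay, cyclobutyl in place of 2-methylphenyl, with the rest of the compound unchanged, gives a modest change beyond the scatter (a 5.7-fold higher number from compound 3 to compound 4 (0.76 log units; beyond the scatter)), so this place also affects the read-out. No measurement shown gives a cause for this step.

On these data alone, it remains open whether the aromatic ring's removal or the lower heavy-atom count drives the step. As far as these compounds go, it also remains open how an open-chain isopropyl group or an amine would read at this place.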